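The source may hold more compounds than are shown below. What is called first, only, known or untested is meant among the compounds shown, and "the series" means these compounds.

In an ADME assay on Vero cells (Chlorocebus sabaeus) for cytotoxicity, read by MTT assay, with a stated time of 72 h (on this read-out lower numbers stand for stronger inhibition and higher numbers for weaker inhibition), the shared core of compound 1, `COc1ccc2c(c1)[n+]([O-])c(C#N)c(-c1ccccc1)[n+]2[O-]`, gives no single number: the entry for compound 1 is "nd(insoluble)" (no result reported), recorded as insoluble. Of the three compounds with an entry, only one has a figure, and a further entry besides compound 1 is also without a number. Compound 2, `Cc1ccc(-c2c(C#N)[n+]([O-])c3cc(Cl)c(Cl)cc3[n+]2[O-])cc1`, is the one with a figure, and in this assay compound 2 gives 0.72 ug/mL. Compound 3, `COc1ccc(-c2c(C#N)[n+]([O-])c3cc(Cl)ccc3[n+]2[O-])cc1`, stands without a result; in this assay compound 3 gives "not determined" (no result reported).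

Compound 4, `COC(=O)c1ccc(-c2c(C#N)[n+]([O-])c3cc(OC)ccc3[n+]2[O-])cc1`, has not been tested in this assay. It differs from compound 1 in one place: methoxycarbonyl in place of hydrogen on an aromatic carbon. Among the compounds with values here, no pair of measured compounds that differ in a single place is available, so no step can be set beside this change. Within the data shown here, with compound 1 giving no number, no direction in this assay can be drawn from it, and the expectation for compound 4 rests on the single figure of compound 2 and on wide uncertainty. Compound 4 is expected to give about 3 ug/mL, within a range estimated from 0.4 ug/mL to 25 ug/mL.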

Compound 4, half-maximal inhibitory concentration: 3.9 ug/mL
Estimate against measurement, compound 4: 1.3-fold (0.11 log units) below; low and high end bracket the measured number.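

No step can be read from compound 1 to compound 4: compound 1 has no single number to set against the figure for compound 4. The compounds shown leave open what methoxycarbonyl in place of hydrogen does to cytotoxicity on the shared core of compound 1. No supporting evidence bears on this result.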